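Cyclohexylamino for octyloxy on a cytotoxicity-free purine scaffold

A few compounds are considered here, and "the series" means these few. Any claim that something is new, unique, unknown or untested is made for them only; others in the source may bear on it.

Compound 1, `CCCCCCCCOc1nc(N)nc2c1ncn2/C=C1/CC1(CO)CO`, was tested in an ADME assay on CCRF-HSB-2 cells (Homo sapiens) for cytotoxicity, with a stated time of 7 days; on this read-out higher numbers stand for lower toxicity in this test and lower numbers for higher toxicity in this test. In this assay compound 1 gives > 20000 nM, which is a limit of the assay rather than a number. Compound 2, `Nc1nc(OCc2ccccc2)c2ncn(/C=C3/CC3(CO)CO)c2n1`, carries phenyl in place of heptyl on a saturated chain carbon bound to an oxygen on an aromatic ring, and in this assay compound 2 gives > 20000 nM, again a limit. Compound 3, `Nc1nc(NCc2ccccc2)c2ncn(/C=C3/CC3(CO)CO)c2n1`, carries benzylamino in place of octyloxy on an aromatic carbon, and in this assay compound 3 gives > 20000 nM, also a limit. The steps among them are therefore a step that the two limits leave unreadable from compound 1 to compound 2, a step that the two limits leave unreadable from compound 1 to compound 3 and a step that the two limits leave unreadable from compound 2 to compound 3; all three compounds stand at the limit of > 20000 nM in this assay, at which 3 of the 3 values shown sit.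

Compound 4, `Nc1nc(NC2CCCCC2)c2ncn(/C=C3/CC3(CO)CO)c2n1`, has not yet been measured. It differs from compound 1 by cyclohexylamino in place of octyloxy on an aromatic carbon. The steps toward benzyloxy and benzylamino bear on this change, yet each of them is unreadable, so no size or direction can be read for the step to compound 4; the one shared observation is that every measured compound rests at the limit, with nothing going against it.

For compound 4 the expected outcome in this assay is another limit, estimated as 30000 nM with a range from 12000 nM to 100000 nM. The step this estimate means, a step that the limit leaves unreadable from compound 1 to compound 4, is expected to stay within the scatter.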

Compound 4, half-maximal cytotoxic concentration: > 20000 nM
Compound 4: a limit, no number; the forecaster's own chance of this, stated with the estimate: 85%; the middle value lies beyond the limit too.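

In this assay, for the compounds shown here, compound 4 also gives a limit rather than a number, so no step linking it to compound 1, compound 2 or compound 3 can be read: the limit of > 20000 nM in this assay, at which 4 of the 4 values shown sit. From the compounds shown here alone, what stays open is how far beyond this limit the true values of the four compounds lie, and whether the groups on this aromatic carbon differ at all.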